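This account rests on a few compounds, and the source may have more. Where it says the series, first, only, none or still open, it means among the compounds named here.

Measured compounds:

Compound 1, `CCN(c1ccc(C#N)c(Cl)c1)c1cc(-c2ccncc2)ccc1C`: 1030 nM
Compound 2, `N#Cc1ccc(N2CCc3cc(-c4ccncc4)ccc3C2)cc1C(F)(F)F`: 6940 nM
Compound 3, `CCN(c1ccc(C#N)c(Cl)c1)c1cc(-c2cccnc2)ccc1C`: 2000 nM

These three compounds were tested in a functional assay on CWR22R cells (Homo sapiens) for antiproliferative activity, read by CCK-8 assay, with a stated time of 6 days; on this read-out higher numbers stand for weaker inhibition and lower numbers for stronger inhibition. In this assay compound 1 gives 1030 nM, compound 3 gives 2000 nM and compound 2 gives 6940 nM. Compound 2 has the highest number of the three, and its gaps to compound 3 and to compound 1 both lie beyond the usual scatter.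

Compounds 1 and 3 share one core and differ in a single place: pyridin-3-yl in place of pyridin-4-yl on an aromatic carbon. That change made a step of a 1.9-fold higher number from compound 1 to compound 3 (0.29 log units; within the scatter), a step within the scatter, so the two values cannot be ordered with confidence.

Compound 2 and compound 1 differ by more than one place, and the difference between the two cores is not broken down here.

The compound still to be measured is compound 4, `N#Cc1ccc(N2CCc3cc(-c4cccnc4)ccc3C2)cc1C(F)(F)F`. It is related to compound 2 in the following way: pyridin-3-yl in place of pyridin-4-yl on an aromatic carbon. This is the same kind of change as from compound 1 to compound 3, but the surroundings differ: in compound 4 the change sits on a six-membered aromatic ring of carbon only that is part of a fused or bridged system of two rings, meta to a fused ring and para to a fused ring, whereas in compound 3 it sits on a ring that is meta to a large group and para to a methyl group. Because the earlier change gave a 1.9-fold higher number from compound 1 to compound 3 (0.29 log units; within the scatter), a similar small step is expected from compound 2 to compound 4, about a 1.7-fold higher number from compound 2 to compound 4 (0.24 log units; within the scatter). Given that compound 2 gives 6940 nM, compound 4 is estimated at 12000 nM in this assay, with a plausible range from 5000 nM to 30000 nM.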

Compound 4, half-maximal inhibitory concentration: 4790 nM
The estimate for compound 4 lay 2.5-fold (0.40 log units) above the measured number; measured number below the stated range.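

In this assay, putting pyridin-3-yl in place of pyridin-4-yl on the second core gave a 1.4-fold lower number from compound 2 to compound 4 (0.16 log units; within the scatter), so this pair, like the pair on the first core, cannot be ordered with confidence. Each step taken alone is small, yet the two steps do not agree closely enough to treat this change as a fixed shift that can simply be copied from one core to the other: the same change on two cores in this assay, a 1.9-fold higher number (0.29 log units; within the scatter) from compound 1 to compound 3 and a 1.4-fold lower number (0.16 log units; within the scatter) from compound 2 to compound 4, 2.8-fold (0.45 log units) apart, beyond the scatter of two such steps. Going by these compounds alone, this shows only that the step measured on one core was a poor guide to the step on the other; with a single pair on each core, it does not show why the two steps differ, nor that either core would repeat its own step with other groups in this place.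

The compounds shown leave open how a plain phenyl ring, a pyridin-2-yl group or a pyridine ring carrying an amine or a carboxylic acid would read in this assay on either core. They also leave open which of the several differences between the two cores matters, since a single swap, such as chlorine for trifluoromethyl with all else held the same, does not appear among them.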